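The compounds below may be only part of what the source reports. "The series", "measured", "known", "first", "only" and "open" are said of these compounds alone.

Measured in a functional assay on HT-29 cells (Homo sapiens) for antiproliferative activity, read by MTT assay, with a stated time of 48 h (on this read-out lower numbers stand for stronger inhibition of growth and higher numbers for weaker inhibition of growth), are these compounds:
Compound 1 `COC(=O)N1N=C(c2ccccc2)CC1c1cc(OC)c(OC)c(OC)c1` gives 6260 nM as a number
Compound 2 `CCCOC(=O)N1N=C(c2ccccc2)CC1c1cc(OC)c(OC)c(OC)c1` gives > 10000 nM as a limit of the assay
Compound 3 `COc1cc(C2CC(c3ccccc3)=NN2C(=O)OCc2ccccc2)cc(OC)c1OC` gives > 10000 nM as a limit of the assay

Compound 1 is the only one of the three with a number, so it has no measured rank against the others. Compound 4 `CCOc1cccc(C2=NN(C(=O)OC)C(c3cc(OC)c(OC)c(OC)c3)C2)c1` carries ethoxy in place of hydrogen on an aromatic carbon. The nearest evidence is an at least 1.5-fold higher number from compound 1 to compound 2 (0.20 log units; that floor lies within the scatter) and an at least 1.5-fold higher number from compound 1 to compound 3 (0.20 log units; that floor lies within the scatter) with both floors within the scatter. Both changes lie on a saturated chain carbon and not on the aromatic carbon, so they set no size or direction here. The estimated 1.0-fold lower number from compound 1 to compound 4 (0.02 log units; within the scatter) is therefore expected to stay within the scatter. Expected for compound 4 in this assay is 6000 nM within an estimated range of 1800 nM to 18000 nM for now.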

Compound 4, concentration for 50% growth inhibition: 4450 nM
Compound 4: the middle estimate sits 1.3-fold (0.13 log units) above what was measured; measured number inside the range.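

In this assay the change from phenyl to 3-ethoxyphenyl gives a 1.4-fold lower number from compound 1 to compound 4 (0.15 log units; within the scatter) and is the first change shown on an aromatic carbon, meta to a large group. Ethoxy is thus tolerated on this carbon without a shift beyond the scatter. Compound 4 also keeps a measured number, whereas the changes on the saturated chain carbon ended at a limit of the assay: the limit of > 10000 nM in this assay, at which 2 of the 4 values shown sit.

From the compounds shown here alone, whether an amine, a carboxylic acid or a longer chain would be tolerated on this carbon remains open. So does the outcome of ethoxy on the other carbons of that ring.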